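Swapping 4-methylpiperidin-1-yl for 4-methylphenyl in compound 1

The source may hold more compounds than are shown below. What is called first, only, known or untested is meant among the compounds shown, and "the series" means these compounds.

Compound 1 `Cc1cc(C)c(S(=O)(=O)N2CCC(N3CCC(C)CC3)CC2)c(C)c1` was tested in an ADME assay on HCT-116 cells (Homo sapiens) for cytotoxicity, read by CellTiter-Glo, with a stated time of 72 h; a lower number here means a stronger inhibitor, a higher number a weaker inhibitor. In this assay compound 1 reaches only a limit, > 5000 nM. Its close relative compound 2 `Cc1cc(C)c(S(=O)(=O)N2CCC(N3CCC(c4ccccc4)CC3)CC2)c(C)c1` also gives only a limit in this assay, > 5000 nM. Compound 3 `Cc1ccc(C#N)c(S(=O)(=O)N2CCC(N3CCC(C)CC3)CC2)c1` likewise returns a limit in this assay, > 5000 nM. Going by the values given here, compound 1 therefore stands at the limit of > 5000 nM in this assay, at which 3 of the 3 values shown sit, and the single step between measured compounds, a step that the two limits leave unreadable from compound 1 to compound 2, cannot be read. Compound 4 `Cc1ccc(C2CCN(S(=O)(=O)c3c(C)cc(C)cc3C)CC2)cc1` differs from compound 1 by 4-methylphenyl in place of 4-methylpiperidin-1-yl on a saturated ring carbon. Among the compounds with values here, no readable measured step bears on this change; the one available comparison, from compound 1 to compound 2, is unreadable. Compound 4 is expected to stay weak in this assay, with an estimated step that the limit leaves unreadable from compound 1 to compound 4. For compound 4 the estimated value is 8000 nM, within 3000 nM to 30000 nM.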

Compound 4, half-maximal inhibitory concentration: > 5000 nM
Compound 4: no number, only a limit (the forecaster's own chance of this, stated with the estimate: 80%); the middle value is on the limit's open side.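

Going by these compounds alone, no step from compound 1 to compound 4 can be read in this assay, as each gives only a limit. How strongly any of the compounds shown acts in this assay stays open: the limit of > 5000 nM in this assay, at which 4 of the 4 values shown sit.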